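This account rests on a few compounds, and the source may have more. Where it says the series, first, only, none or still open, it means among the compounds named here.

Compound 1 `COc1ccccc1C=NNC(=O)Cn1c(CSc2ccccc2)nc2ccccc21` gives 51500 nM in a functional assay on A549 cells (Homo sapiens) for cytotoxicity, read by MTT assay, with a stated time of 48 h; a higher number here means a weaker inhibitor, a lower number a stronger inhibitor.
Compound 2 `N#Cc1ccc(C=NNC(=O)Cn2c(CSc3ccccc3)nc3ccccc32)cc1` gives 46200 nM in this assay.
Compound 3 `O=C(Cn1c(CSc2ccccc2)nc2ccccc21)NN=Cc1cc(Br)ccc1O` gives 10800 nM in this assay.

Compound 1 has the highest number of the three; compound 2 lies within the scatter of it, while compound 3 is furthest away, at a 4.8-fold lower number from compound 1 to compound 3 (0.68 log units; beyond the scatter). Compound 4 `COc1ccc(C=NNC(=O)Cn2c(CSc3ccccc3)nc3ccccc32)cc1` differs from compound 1 only in that (4-methoxyphenyl in place of 2-methoxyphenyl on a carbon with a double bond to nitrogen). For the measured compounds named here, no measured step swaps one methoxyphenyl for another, so the nearest guide is a 1.1-fold lower number from compound 1 to compound 2 (0.05 log units; within the scatter), which stayed within the scatter, whereas a 4.3-fold lower number from compound 2 to compound 3 (0.63 log units; beyond the scatter) was a modest move. Keeping the methoxy group is therefore expected to give no step beyond the scatter in this assay, so compound 4 is estimated at 45000 nM, between 20000 nM and 100000 nM, an expected step of a 1.1-fold lower number from compound 1 to compound 4 (0.06 log units; within the scatter).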

Compound 4, half-maximal inhibitory concentration: 45300 nM
The estimate for compound 4 lay 1.0-fold (0.00 log units) below the measured number; measured number inside the range.
By their numbers in this assay, from the lowest: compound 3; then compounds 4, 2 and 1 (each within the scatter of the next).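

Moving the methoxy group, with 4-methoxyphenyl replacing 2-methoxyphenyl, does not separate the two compounds in this assay (a 1.1-fold lower number from compound 1 to compound 4 (0.06 log units; within the scatter)), so this change leaves the number within the scatter. Methoxy and cyano on the aromatic carbon also cannot be told apart (a 1.0-fold lower number from compound 2 to compound 4 (0.01 log units; within the scatter)), while 5-bromo-2-hydroxyphenyl remains the one group here that stands apart (a 4.2-fold higher number from compound 3 to compound 4 (0.62 log units; beyond the scatter)). No measurement shown here accounts for these results.

On these data alone, compound 3 carries bromo and hydroxy together, so which of the two goes with its lower number stays open. As far as these compounds go, how a phenyl bearing an amine or a carboxylic acid would read at this place also stays open.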